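This account rests on a few compounds, and the source may have more. Where it says the series, first, only, none or still open, it means among the compounds named here.

In a physicochemical assay for solubility, in phosphate buffer, at pH 6.8 (on this read-out lower numbers stand for lower solubility and higher numbers for higher solubility), compound 1 `CCn1c(NC2CC2)nc2ccsc2c1=O` gives 430 ug/mL. Compound 3 `CCn1c(NC(C)C)nc2c(C3CCCN(C(C)=O)C3)csc2c1=O` gives 230 ug/mL, within the usual scatter of compound 1. Compound 2 `CCn1c(NC(C)C)nc2c(-c3cncnc3)csc2c1=O` gives 18 ug/mL, and the gap between compound 1 and compound 2 lies beyond the scatter. Compound 1 therefore shares the upper end of these three numbers with compound 3.

Compound 4 `CCNc1nc2ccsc2c(=O)n1CC` has not yet been measured. Its difference from compound 1 is ethyl in place of cyclopropyl on a nitrogen on an aromatic ring, or cyclopropylamino to ethylamino. Among the compounds with values here, no two measured compounds differ in one place, so the series offers no direct precedent for this change. In this assay, no step beyond the scatter is expected, but this remains an expectation without a measured pair behind it. The estimated step is a 1.0-fold higher number from compound 1 to compound 4 (0.02 log units; within the scatter). This step is anchored on compound 1, which gives 430 ug/mL. For compound 4, the estimated value is 450 ug/mL, with an expected range of 180 ug/mL to 1100 ug/mL.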

Compound 4, solubility: 240 ug/mL
For compound 4 the middle estimate is 1.9-fold (0.27 log units) above the measured one, within the range that was stated.
By their numbers in this assay, from the lowest: compound 2; then compounds 3, 4 and 1 (each within the scatter of the next).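

In this assay, ethyl in place of cyclopropyl on a nitrogen on an aromatic ring is a step of a 1.8-fold lower number from compound 1 to compound 4 (0.25 log units; within the scatter). This is the only pair shown that differs in one place, and it gives this position its first measured precedent: on the core of compound 1, cyclopropylamino and ethylamino cannot be told apart on this read-out. No measured evidence bears on why the two compounds read alike.

Open, from the compounds shown here alone, is whether a longer chain such as n-butyl, or an amine-bearing chain such as 2-aminoethyl, on this nitrogen would also stay within the scatter of compound 1. Also open, going by these compounds, is whether this step carries over to compound 2 and compound 3, which differ from compound 1 in more than one place.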